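The source may report more compounds than this note shows. Statements on the series, on what has been measured and on what is new or still open speak of the compounds shown alone.

Measured so far:
compound 1, `CC(C)CCn1nc(C2CCCC2)c(O)c(C2=NS(=O)(=O)c3cc(NS(C)(=O)=O)ccc3N2)c1=O`: 0.283 h
compound 2, `CC(C)(C)CCn1nc(-c2cccs2)c(O)c(C2=NS(=O)(=O)c3cc(NS(C)(=O)=O)ccc3N2)c1=O`: > 1 h

In an in vitro ADME assay on microsomes from liver (Homo sapiens) for metabolic stability, tested at 5 uM (a lower number here means that the compound disappears faster, a higher number that the compound lasts longer), compound 1 gives 0.283 h. For compound 2 the measurement gives only a limit, > 1 h, so its half-life is not known as a number. Compound 2 therefore stands at the limit of > 1 h in this assay, at which 1 of the 2 values shown sits, the upper edge of what was reported. Compound 3, `CS(=O)(=O)Nc1ccc2c(c1)S(=O)(=O)N=C(c1c(O)c(-c3cccs3)nn(Cc3ccc(F)cc3)c1=O)N2`, has not yet been measured. It differs from compound 2 in a single place: 4-fluorophenyl in place of neopentyl on a saturated chain carbon bound to an aromatic nitrogen. Within the data shown here, no measured pair of compounds shows this particular change, so the size of its effect can only be expected, not read off. The step of an at least 1.2-fold lower number from compound 2 to compound 3 (0.09 log units; that floor lies within the scatter) is expected to be a modest fall in half-life, close to the edge of the usual scatter rather than a large shift. Compound 3 is estimated at 0.8 h in this assay, with a range from 0.3 h to 2 h.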

Compound 3, half-life: > 1 h
Compound 3 was reported as a limit; the forecaster's own chance of this, stated with the estimate: 35%; at least 1.2-fold (0.09 log units) between middle value and limit.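

Compound 2 and compound 3 both reach only a limit in this assay, so no step between them can be read: the limit of > 1 h in this assay, at which 2 of the 3 values shown sit.

The compounds shown leave open what half-life either compound really has, and so whether 4-fluorophenyl in place of neopentyl changes it at all.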